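Swapping chlorine for fluorine on a chalcone-pyrazole pair

This account rests on a few compounds, and the source may have more. Where it says the series, first, only, none or still open, it means among the compounds named here.

Measured compounds:
compound 1 `COc1ccc(-c2cc(/C=C/C(=O)c3ccc(N)cc3)[nH]n2)cc1`, 87%
compound 2 `COc1cc(-c2cc(/C=C/C(=O)c3ccc(Cl)c(Cl)c3)[nH]n2)cc(OC)c1OC`, 95%

Of the compounds shown here, two have been measured in a functional assay on Malme-3M cells (Homo sapiens) for cytotoxicity, read by sulforhodamine B assay, with a stated time of 48 h, tested at 1 uM; a lower number here means a stronger effect, a higher number a weaker effect of the compound at the concentration tested. Compound 1 `COc1ccc(-c2cc(/C=C/C(=O)c3ccc(N)cc3)[nH]n2)cc1` gives 87%, and compound 2 `COc1cc(-c2cc(/C=C/C(=O)c3ccc(Cl)c(Cl)c3)[nH]n2)cc(OC)c1OC` gives 95%. The two values lie within the scatter of each other, so neither compound can be called more or less active than the other; both leave most of the cells unharmed at the concentration tested. Compound 2 holds the higher of the two numbers, but only by a margin that repeated measurements of this kind would blur.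

Compound 3 `COc1cc(-c2cc(/C=C/C(=O)c3ccc(F)c(F)c3)[nH]n2)cc(OC)c1OC` has not yet been measured in this assay. It differs from compound 2 in one place: 3,4-difluorophenyl in place of 3,4-dichlorophenyl on a carbonyl carbon. Going by the values given here, no measured pair shows what this particular exchange does, so nothing from the data itself points in a direction. Given that both measured compounds sit close to one another with weak effects, the expectation for compound 3 is a step no larger than the scatter, in either direction, as a number 3 percentage points lower from compound 2 to compound 3 (within the scatter). The estimated value for compound 3 is 92%, in a range from 76% to 105%.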

Compound 3, a percentage reported as activity, at one concentration (the size of the read-out at that concentration, not a potency): 97%
For compound 3 the middle estimate is 5 percentage points below the measured one, and the stated range covers the measured number.
By their numbers in this assay, from the lowest: compounds 1, 2 and 3 (each within the scatter of the next).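

In this assay, the step from 3,4-dichlorophenyl to 3,4-difluorophenyl on the carbonyl carbon gives a number 2 percentage points higher from compound 2 to compound 3 (within the scatter), and this is the first pair shown that differs in one place only. Going by these compounds alone, compound 2 and compound 3 therefore cannot be told apart, so at this position and at the single concentration tested, this exchange of one halogen pair for another leaves no readable mark on the result, although it is only one pair and supports no general rule about the position. Nothing shown explains why the two compounds read alike, and no outside measurement bears on the result.

Compound 1 differs from compound 2 and compound 3 in more than one place, so it cannot show what its own aminophenyl group contributes at this position. From the compounds shown here alone, it also remains open what a quite different group on this phenyl ring, such as a carboxylic acid or a nitrile, would do, and whether any such compound would give a number clearly lower than these in this assay.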